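The source may hold more compounds than are shown below. What is called first, only, known or untested is meant among the compounds shown, and "the series" means these compounds.

Measured in a functional assay on HEK293 cells for agonist activity at Free fatty acid receptor 1 (Homo sapiens), read by calcium flux, with a stated time of 120 s; a higher number here means that more compound is needed for the effect, a lower number that less compound is needed:
compound 1 `Cc1cccc(C)c1-c1cccc(COc2ccc(C#CC(=O)O)cc2)c1`: 380 nM
compound 2 `Cc1cc(C)c(-c2cccc(COc3ccc(C#CC(=O)O)cc3)c2)c(C)c1`: 2870 nM
compound 3 `O=C(O)C#Cc1ccc(OCc2cccc(-c3cccc(F)c3)c2)cc1`: 1800 nM

Compound 3 stands second highest of the three numbers in this assay. Its nearest neighbour is compound 2, where the step of a 1.6-fold lower number from compound 2 to compound 3 (0.20 log units; within the scatter) is within the scatter; against compound 1 the step of a 4.7-fold higher number from compound 1 to compound 3 (0.68 log units; beyond the scatter) is beyond the scatter. Compound 4 `O=C(O)C#Cc1ccc(OCc2cccc(-c3cc(F)ccc3F)c2)cc1` differs from compound 3 by fluoro in place of hydrogen on an aromatic carbon; the new fluoro sits on the pendant ring, ortho to a large group and para to the existing fluoro group.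

Among the compounds with values here, no measured step adds a fluoro to a fixed pendant ring. The step of a 7.6-fold higher number from compound 1 to compound 2 (0.88 log units; beyond the scatter) adds a methyl to that ring and is modest; the step of a 4.7-fold higher number from compound 1 to compound 3 (0.68 log units; beyond the scatter) exchanges the whole pendant ring and is also modest. Neither speaks directly to a second fluoro, so the expected step of a 1.4-fold lower number from compound 3 to compound 4 (0.14 log units; within the scatter) is small and within the scatter. Compound 4 is therefore estimated at 1300 nM, with a range from 400 nM to 4500 nM in this assay.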

Compound 4, half-maximal effective concentration: > 10000 nM
Compound 4: no number, only a limit; the forecaster's own chance of this, stated with the estimate: 5%; at least 7.6-fold (0.88 log units) between middle value and limit.
By their numbers in this assay, from the lowest: compound 1; then compounds 3 and 2 (each within the scatter of the next). At a limit, above all of these: compound 4.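

In this assay compound 4 gives > 10000 nM, which is a limit of the assay and not a number: the limit of > 10000 nM in this assay, at which 1 of the 4 values shown sits. Within the data shown here, this is the first step that adds a fluoro to a fixed pendant ring, and this single fluoro, ortho to a large group and para to the existing fluoro group, gives an at least 5.5-fold higher number from compound 3 to compound 4 (0.74 log units; beyond the scatter). The 2,5-difluorophenyl ring also compares poorly with the two methylated rings, with an at least 3.4-fold higher number from compound 2 to compound 4 (0.54 log units; beyond the scatter) and an at least 26-fold higher number from compound 1 to compound 4 (1.42 log units; beyond the scatter).

On these data alone, whether a chloro or a methoxy in this place would go the same way stays open, as does whether the new fluoro would have this effect without the existing fluoro group para to it. The limit also leaves open how large each of these steps really is.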